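A few compounds are considered here, and "the series" means these few. Any claim that something is new, unique, unknown or untested is made for them only; others in the source may bear on it.

Measured so far:

Compound 1, `CCCc1cnc(C(=O)/C=C/c2ccc(O)cc2)cn1`, in a functional assay on the whole organism for inhibition, with Spinacia oleracea as the target, read by spectrophotometry, with a stated time of 4 h (on this read-out higher numbers stand for weaker inhibition and lower numbers for stronger inhibition), compound 1 gives 399000 nM.
Compound 2, `CC(C)c1cnc(C(=O)/C=C/c2ccccc2O)cn1`, in this assay compound 2 gives 167000 nM.
Compound 3, `CCCCCCCCSc1cc(C(N)=S)ccn1`, in this assay compound 3 gives 72000 nM.

Among these three numbers compound 2 stands second highest. Compound 3 sits below it by more than the usual scatter, and compound 1 sits above it by more than the usual scatter, so compound 2 holds the middle ground on this small set. Among the compounds with values here, no two measured compounds differ in just one place, so there is no directly comparable step to lean on.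

The next compound, compound 4, `CCCCc1cnc(C(=O)/C=C/c2ccccc2O)cn1`, is made from compound 2 by one change: butyl in place of isopropyl on an aromatic carbon. The chain on the ring grows by one carbon and loses its branching, while the rest of the molecule, including the phenol and the linking chain, stays the same. With no measured step of this kind in hand, a small shift is expected, most likely within the usual scatter, in either direction. The estimated step is a 1.1-fold lower number from compound 2 to compound 4 (0.05 log units; within the scatter), and compound 4 is expected to give about 150000 nM, within a range from 50000 nM to 450000 nM.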

Compound 4, half-maximal inhibitory concentration: 184000 nM
The estimate for compound 4 lay 1.2-fold (0.09 log units) below the measured number, and the stated range covers the measured number.
By their numbers in this assay, from the lowest: compound 3; then compounds 2 and 4 (each within the scatter of the next); then compound 1.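

Within the data shown here, this pair gives the first direct reading at this position, the aromatic carbon next to the ring nitrogen: in this assay, butyl in place of isopropyl gives a 1.1-fold higher number from compound 2 to compound 4 (0.04 log units; within the scatter), so the two chains cannot be told apart here. On this one pair, then, the unbranched butyl chain and the branched isopropyl group serve equally well in this read-out, and the position tolerates this swap without a change beyond the scatter. Nothing available explains this outcome.

Going by these compounds, whether a much longer chain such as decyl, or a different kind of group such as an amine or a carboxylic acid, would shift the number on this carbon remains open. So does whether the same swap would behave alike with the phenol hydroxyl placed as in compound 1.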